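Oxamide anilides on the shared core: fluoro to hydroxy

This account rests on a few compounds, and the source may have more. Where it says the series, first, only, none or still open, it means among the compounds named here.

Measured so far:
compound 1, `CC(C)(C)c1ccc(/C=C/C(=O)Nc2ccc3c(c2)COC3=O)cc1`: 720 nM
compound 2, `CC(C)(C)NC(=O)C(=O)Nc1ccc2c(c1)COC2=O`: 3400 nM
compound 3, `O=C(Nc1ccc(F)cc1)C(=O)Nc1ccc2c(c1)COC2=O`: 570 nM

In a functional assay on cells (T-cell, Mus musculus) for inhibition (a lower number here means a stronger inhibitor, a higher number a weaker inhibitor), compound 3 gives the lowest of the three numbers. Going by the values given here, compound 1 stands within the scatter of compound 3; compound 2 stands apart, and the one step in the set, a 6.0-fold lower number from compound 2 to compound 3 (0.78 log units; beyond the scatter), is beyond the scatter and of modest size. That step swaps a tert-butyl for a 4-fluorophenyl on an amide-type nitrogen; it says nothing about what a change on the aromatic ring itself does.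

Compound 4, `O=C(Nc1ccc(O)cc1)C(=O)Nc1ccc2c(c1)COC2=O`, differs from compound 3 by hydroxy in place of fluoro on an aromatic carbon. Among the compounds with values here, no measured pair bears on a substituent exchange on that ring, so the expectation rests on the single heavy atom that changes and on compound 3 alone. The estimate for compound 4 in this assay is 800 nM, with a range of 250 nM to 2500 nM. The step this estimate means, a 1.4-fold higher number from compound 3 to compound 4 (0.15 log units; within the scatter), is expected to stay within the scatter, with no direction asserted.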

Compound 4, half-maximal inhibitory concentration: 5030 nM
Compound 4: the middle estimate sits 6.3-fold (0.80 log units) below what was measured; the measured number lies above the stated range.
By their numbers in this assay, from the lowest: compounds 3 and 1 (each within the scatter of the next); then compounds 2 and 4 (each within the scatter of the next).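

Exchanging 4-fluorophenyl for 4-hydroxyphenyl is the first change shown on the aromatic ring itself, and in this assay the ring substituent proves to matter: an 8.8-fold higher number from compound 3 to compound 4 (0.95 log units; beyond the scatter) for a swap of a single heavy atom, on an aromatic carbon para to a large group. The advantage of compound 3 over compound 2 therefore does not carry over to every aryl group, since a 1.5-fold higher number from compound 2 to compound 4 (0.17 log units; within the scatter) leaves the 4-hydroxyphenyl compound level with the tert-butyl compound. Nothing available explains the size of this step.

With only fluoro and hydroxy shown at this position, it remains open whether methoxy, chloro or an amine would track compound 3 or compound 4. Also open, on these data alone, is whether hydrogen at this position, the plain phenyl, would stand nearer compound 3 or compound 4.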